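Bromophenyl Ketone on the Shared Core: Expected Cytotoxicity

The compounds below may be only part of what the source reports. "The series", "measured", "known", "first", "only" and "open" are said of these compounds alone.

Compound 1 `CC1(C)S[C@@H]2/C(=C\C(=O)c3ccc4ccccc4c3)C(=O)N2[C@H]1C(=O)OC(c1ccccc1)c1ccccc1` carries a (naphthalen-2-yl)carbonyl on the shared core. For the measured compounds named here, in a functional assay on A-375 cells (Homo sapiens) for cytotoxicity, read by MTT assay, with a stated time of 48 h (a lower number here means a stronger inhibitor, a higher number a weaker inhibitor), compound 1 gives 36500 nM, the highest number among the three compounds measured so far. Compound 2 `CC1(C)S[C@@H]2/C(=C\C(=O)c3ccc(C(F)(F)F)cc3)C(=O)N2[C@H]1C(=O)OC(c1ccccc1)c1ccccc1` gives 26700 nM in this assay, and compound 3 `CC1(C)S[C@@H]2/C(=C\C(=O)OC(c3ccccc3)c3ccccc3)C(=O)N2[C@H]1C(=O)OC(c1ccccc1)c1ccccc1` gives 9100 nM, which stands beyond the scatter below compound 1.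

Compound 4 `CC1(C)S[C@@H]2/C(=C\C(=O)c3ccc(Br)cc3)C(=O)N2[C@H]1C(=O)OC(c1ccccc1)c1ccccc1` has not been measured. It differs from compound 1 as follows: 4-bromophenyl in place of naphthalen-2-yl on a carbonyl carbon.

Going by the values given here, the one measured step that bears on this change is a 1.4-fold lower number from compound 1 to compound 2 (0.14 log units; within the scatter), where a single substituted phenyl likewise replaced the naphthalen-2-yl on the carbonyl carbon. That step stayed within the scatter. Compound 3, with a benzhydryl ester in place of the aryl ketone, is a different kind of change and is not a guide here. The step from compound 1 to compound 4 is therefore expected to be small, if anything a modestly lower number, in line with a 1.3-fold lower number from compound 1 to compound 4 (0.12 log units; within the scatter).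

On that basis compound 4 is estimated at 28000 nM in this assay, with a range from 12000 nM to 60000 nM.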

Compound 4, half-maximal inhibitory concentration: 29700 nM
The estimate for compound 4 lay 1.1-fold (0.03 log units) below the measured number, within the range that was stated.
By their numbers in this assay, from the lowest: compound 3; then compounds 2, 4 and 1 (each within the scatter of the next).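

Exchanging the naphthalen-2-yl for 4-bromophenyl on the carbonyl carbon gave a 1.2-fold lower number from compound 1 to compound 4 (0.09 log units; within the scatter), so a second substituted phenyl, with one six-membered aromatic ring in place of two, now reads level with the naphthalen-2-yl group of compound 1. For the compounds shown here, the new compound also gives the first comparison of two substituents on that phenyl ring, with bromo in place of trifluoromethyl on an aromatic carbon giving a 1.1-fold higher number from compound 2 to compound 4 (0.05 log units; within the scatter), so neither the exchange of aryl group nor the exchange of ring substituent has moved the number beyond the scatter. No measurement presented here accounts for how closely these three aryl ketones agree.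

As far as these compounds go, it remains open whether an amine or a carboxylic acid on the phenyl ring would separate from bromo and trifluoromethyl, since both of those substituents give the same reading within the scatter. The compounds shown also leave open how a cyclohexyl ring or a longer alkyl chain would read in place of the aromatic group on the carbonyl carbon.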